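The compounds below may be only part of what the source reports. "The series", "measured", "known", "first", "only" and "open" are said of these compounds alone.

In an ADME assay on HEp-2 cells (Homo sapiens) for cytotoxicity, read by MTT assay, with a stated time of 72 h (a higher number here means a weaker inhibitor, a lower number a stronger inhibitor), compound 2 `COc1cc(C2=C(c3ccccc3)C(O[SiH2]C(C)(C)C)CC2=O)cc(OC)c1OC` gives only a limit of the assay, > 100 ug/mL. Compound 1 `COc1ccc(C2=C(c3cc(OC)c(OC)c(OC)c3)C(=O)CC2O[SiH2]C(C)(C)C)cc1OC` likewise reaches only a limit, > 100 ug/mL. Going by the values given here, the one measured step, a step that the two limits leave unreadable from compound 1 to compound 2, is thus of unreadable size, and both values sit at the limit of > 100 ug/mL in this assay, at which 2 of the 2 values shown sit. Compound 3 `COc1ccc(C2=C(c3cc(OC)c(OC)c(OC)c3)C(=O)CC2O[SiH2]C(C)(C)C)cc1O` differs from compound 2 by 3-hydroxy-4-methoxyphenyl in place of phenyl on a double-bonded ring carbon. Among the compounds with values here, no measured step speaks to this change, and the two limits show no direction. The step expected from compound 2 to compound 3, a step that the limit leaves unreadable from compound 2 to compound 3, is therefore none beyond the scatter. Compound 3 is expected to give 150 ug/mL, within 60 ug/mL to 400 ug/mL, most likely again reported as a limit.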

Compound 3, half-maximal inhibitory concentration: 14.5 ug/mL
Compound 3: middle estimate off by 10-fold (1.01 log units), on the high side; measured number below the stated range.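

Compound 3 shows that the group on the double-bonded ring carbon can change the result, with 3-hydroxy-4-methoxyphenyl in place of phenyl giving an at least 6.8-fold lower number from compound 2 to compound 3 (0.83 log units; beyond the scatter). Hydrogen in place of methyl on an oxygen on an aromatic ring alone gives an at least 6.8-fold lower number from compound 1 to compound 3 (0.83 log units; beyond the scatter), so a single free hydroxy group separates compound 3 from compound 1. Both sizes are only minimum sizes, as compound 1 and compound 2 stay at a limit: the limit of > 100 ug/mL in this assay, at which 2 of the 3 values shown sit.

Going by these compounds, the true sizes of both steps remain open. So does whether an amine or a carboxylic acid in place of that hydroxy group would give a similar result.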